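The compounds below may be only part of what the source reports. "The series", "measured", "known", "first", "only" and "open" are said of these compounds alone.

Measured in an assay for inhibition of Indoleamine 2,3-dioxygenase 1 (Homo sapiens), with stated times of 10 min and 60 min, tested at 100 uM; a lower number here means a weaker effect, a higher number a stronger effect of the compound at the concentration tested:
compound 1 `Oc1ccc(CNc2cc(C(F)(F)F)cc3[nH]ncc23)cc1` gives 81%
compound 2 `O=[N+]([O-])c1ccc(CNc2cc(Br)cc3[nH]ncc23)cc1` gives 87%
compound 3 `O=[N+]([O-])c1ccccc1CNc1cc(Br)cc2[nH]ncc12` gives 83%

Compound 2 carries the highest of the three numbers, but its gap to compound 3 and its gap to compound 1 both lie within the scatter, so no order among the three can be read from these values. Compound 4 `O=[N+]([O-])c1ccc(CNc2cc(C(F)(F)F)cc3[nH]ncc23)cc1` has not yet been measured; it differs from compound 2 by trifluoromethyl in place of bromo on an aromatic carbon. Going by the values given here, compound 1 already carries trifluoromethyl at that place and sits within the scatter of compound 2 in this assay, though its other substituent differs, so no one-place step between measured compounds exists. For compound 4 the expected step is a number 3 percentage points lower from compound 2 to compound 4 (within the scatter), none beyond the scatter. Compound 4 is estimated at 84%, in the range 72% to 94%.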

Compound 4, a percentage reported as inhibition, at one concentration (the size of the read-out at that concentration, not a potency): 61%
Compound 4: the middle estimate sits 23 percentage points above what was measured; the measured number lies below the stated range.
By their numbers in this assay, from the lowest: compound 4; then compounds 1, 3 and 2 (each within the scatter of the next).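

In this assay trifluoromethyl in place of bromo gives a number 26 percentage points lower from compound 2 to compound 4 (beyond the scatter) and so shows, in a one-place step, that this aromatic carbon of the core affects the read-out. With trifluoromethyl held fixed, nitro in place of hydroxy gives a number 20 percentage points lower from compound 1 to compound 4 (beyond the scatter) and shows that the nitro and hydroxy place matters as well. No measurement here explains either step.

Going by these compounds, whether chloro or methyl at the bromo place stays with compound 2 or falls with compound 4 remains open. So does where an amine in place of nitro would stand.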